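The compounds below may be only part of what the source reports. "The series", "measured", "known", "first", "only" and "open" are said of these compounds alone.

Measured so far in a physicochemical assay for solubility, in phosphate buffer, at pH 7.4; a higher number here means a more soluble compound, a lower number a less soluble compound:
compound 1, `CC(=O)N[C@@H]1CCC[C@H](C(=O)Nc2cc(-c3cnn4c3CC(C)(C)CC4)ccn2)C1`: 640000 nM
compound 2, `CC(=O)N[C@@H]1CCC[C@H](C(=O)Nc2cc(-c3cnn4c3CC(C)(C)CC4)c(F)cn2)C1`: 160000 nM
compound 3, `CC(=O)N[C@@H]1CCC[C@H](C(=O)Nc2cc(-c3cnn4c3CC(C)(C)C4)ccn2)C1`: 970000 nM

Compound 1 and compound 2 share a core and differ in one place, (fluoro in place of hydrogen on an aromatic carbon). That single change is tied to a 4.0-fold lower number from compound 1 to compound 2 (0.60 log units; beyond the scatter). Compound 3 carries a different core from compound 1; the difference between the two cores is not broken down here. In this assay compound 3 and compound 1 lie within the scatter of each other, so no order between them is claimed, whereas compound 2 lies beyond the scatter from both of them.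

Compound 4, `CC(=O)N[C@@H]1CCC[C@H](C(=O)Nc2cc(-c3cnn4c3CC(C)(C)C4)c(F)cn2)C1`, is not yet measured in this assay. For the measured compounds named here, it differs from compound 3 by fluoro in place of hydrogen on an aromatic carbon, which is the same change as the one from compound 1 to compound 2, with an identical description of the place. Going by the values given here, with only one prior instance of this change, the expectation for compound 4 rests on a 4.0-fold lower number from compound 1 to compound 2 (0.60 log units; beyond the scatter) alone, and a step of similar size is expected, a 4.0-fold lower number from compound 3 to compound 4 (0.61 log units; beyond the scatter). On that basis compound 4 is estimated at 240000 nM in this assay, expected to fall between 120000 nM and 500000 nM.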

Compound 4, solubility: 550000 nM
For compound 4 the middle estimate is 2.3-fold (0.36 log units) below the measured one; measured number above the stated range.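

In this assay, fluoro in place of hydrogen on the aromatic carbon gives a 1.8-fold lower number from compound 3 to compound 4 (0.25 log units; within the scatter), whereas the same change on the core of compound 1 gives a 4.0-fold lower number from compound 1 to compound 2 (0.60 log units; beyond the scatter). The step beyond the scatter on the core of compound 1 therefore does not recur beyond the scatter on the core of compound 3, but two matched pairs do not show whether the core truly sets the size of this step or how far the two steps differ. No measurement shown bears on the reason for this result.

The compounds shown carry only hydrogen or fluoro on this aromatic carbon, so it remains open how chloro, methoxy or an amine there would read on either core. On these data alone, it also remains open whether a third core would give a step closer to that of the first pair or the second.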